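The source may hold more compounds than are shown below. What is called first, only, known or untested is meant among the compounds shown, and "the series" means these compounds.

Measured compounds:
compound 1 `CN1CCC(NC(=O)c2ccncc2Nc2cc(-c3ccc4ccn(C)c4c3)c3nccnc3c2)CC1` — in an assay on lysate for inhibition of 6-phosphofructo-2-kinase/fructose-2,6-bisphosphatase 3 (Homo sapiens), with stated times of 0.5 min and 45 min (on this read-out higher numbers stand for weaker inhibition and lower numbers for stronger inhibition), compound 1 gives 19500 nM
compound 2 `CC(=O)N1CCCC(NC(=O)c2ccncc2Nc2cc(-c3ccc4ccn(C)c4c3)c3nccnc3c2)C1` — in this assay compound 2 gives 13500 nM

Among the compounds with values here, compound 2 has only one measured neighbour, compound 1, and the step between them, a 1.4-fold lower number from compound 1 to compound 2 (0.16 log units; within the scatter), lies within the scatter, so compound 2 cannot be set apart from compound 1 on these numbers. Compound 3 `CC(=O)N1CC(CNC(=O)c2ccncc2Nc2cc(-c3ccc4ccn(C)c4c3)c3nccnc3c2)C1` differs from compound 2 by (1-acetylazetidin-3-yl)methyl in place of 1-acetylpiperidin-3-yl on an amide-type nitrogen. Within the data shown here, the one measured step also changed the group on this amide-type nitrogen and moved the number only within the scatter, so no step beyond the scatter is expected here, no change at the digits printed from compound 2 to compound 3 (within the scatter). Compound 3 is expected to give about 13500 nM in this assay, between 5000 nM and 40000 nM.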

Compound 3, half-maximal inhibitory concentration: > 100000 nM
Compound 3 was reported as a limit; the forecaster's own chance of this, stated with the estimate: 10%; middle value at least 7.4-fold (0.86 log units) away from the limit.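

Compound 3 is reported only as a limit of the assay: the limit of > 100000 nM in this assay, at which 1 of the 3 values shown sits.

Even so, this position on the amide-type nitrogen is not indifferent to its group in this assay: the change to (1-acetylazetidin-3-yl)methyl gives an at least 7.4-fold higher number from compound 2 to compound 3 (0.86 log units; beyond the scatter) and an at least 5.1-fold higher number from compound 1 to compound 3 (0.70 log units; beyond the scatter), whereas the earlier change gave only a 1.4-fold lower number from compound 1 to compound 2 (0.16 log units; within the scatter).

The ring and the methyl link changed together, so the compounds shown cannot say which of them counts. A 1-acetylazetidin-3-yl or a (1-acetylpiperidin-3-yl)methyl group on the same nitrogen would separate the two.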